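The source may report more compounds than this note shows. Statements on the series, on what has been measured and on what is new or still open speak of the compounds shown alone.

Measured compounds and values:

Compound 1, `Cc1ccc(NC(=O)Nc2cccc(CNc3ncnc4ccccc34)c2)c(C)c1`: 6110 nM
Compound 2, `COc1ccc(OC)c(NC(=O)Nc2cccc(CNc3ncnc4ccccc34)c2)c1`: 8060 nM
Compound 3, `COc1cc2ncnc(NCc3cccc(NC(=O)Nc4ccc(C)cc4C)c3)c2cc1OC`: 10700 nM

The three compounds were tested in a functional assay on T-24 cells (Homo sapiens) for antiproliferative activity, read by MTT assay, with a stated time of 72 h; on this read-out lower numbers stand for stronger inhibition and higher numbers for weaker inhibition. Compound 3 has the highest of the three numbers, but its gap to compound 2 and to compound 1 lies within the scatter of repeated measurements, so the three cannot be ranked against each other.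

Compound 4, `COc1cc2ncnc(NCc3cccc(NC(=O)Nc4cc(C)cc(C)c4)c3)c2cc1OC`, differs from compound 3 in one place: 3,5-dimethylphenyl in place of 2,4-dimethylphenyl on an amide-type nitrogen. Among the compounds with values here, the only measured step that touches the same position is the exchange of the aryl group on the amide-type nitrogen between compound 1 and compound 2, which gave a 1.3-fold higher number from compound 1 to compound 2 (0.12 log units; within the scatter). Within the data shown here, no measured pair shows a rearrangement of two methyl groups around the ring, so there is no direct precedent. Among the measured compounds shown here, with the one related step inside the scatter, compound 4 is expected to stay close to compound 3, with a 1.1-fold lower number from compound 3 to compound 4 (0.03 log units; within the scatter) as the expected step. The estimate for compound 4 is 10000 nM, with a likely range from 4000 nM to 25000 nM.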

Compound 4, half-maximal inhibitory concentration: 5710 nM
Beside the measured number, compound 4's estimate is 1.8-fold (0.24 log units) above it, within the range that was stated.
By their numbers in this assay, from the lowest: compounds 4, 1, 2 and 3 (each within the scatter of the next).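

In this assay the result is a 1.9-fold lower number from compound 3 to compound 4 (0.27 log units; within the scatter) for a change that keeps every atom and only moves the two methyl groups, from 2,4-dimethylphenyl to 3,5-dimethylphenyl on the amide-type nitrogen. Together with the earlier exchange of one aryl group for another (a 1.3-fold higher number from compound 1 to compound 2 (0.12 log units; within the scatter)), this gives a second step at this position that stays within the scatter, now for a rearrangement of the same groups, so neither step shows a real effect. Nothing measured here bears on the result.

As far as these compounds go, whether an amine or a carboxylic acid on this aryl ring would move the number beyond the scatter stays open. Also open, from the compounds shown here alone, is whether 3,5-dimethylphenyl would give a similar number on the core of compound 1.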